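Shortening the Ester Chain of Compound 1

The source may hold more compounds than are shown below. What is called first, only, known or untested is meant among the compounds shown, and "the series" means these compounds.

Measured so far:
compound 1, `CCCCCCCCCCC(C)OC(=O)CC(=O)Nc1c(C(C)C)cccc1C(C)C`: 6 nM
compound 2, `CC(C)c1cccc(C(C)C)c1NC(=O)CC(=O)Oc1c(-c2ccccc2)cccc1-c1ccccc1`: 67 nM
compound 3, `CC(C)c1cccc(C(C)C)c1OC(=O)CC(=O)Nc1c(F)cccc1F`: 6200 nM

In an assay on microsomes from intestine for inhibition of acyl-CoA:cholesterol acyltransferase (Oryctolagus cuniculus) (a higher number here means a weaker inhibitor, a lower number a stronger inhibitor), compound 1 gives 6 nM, the lowest number of the three and therefore the strongest inhibitor among them. Compound 2 gives 67 nM, and compound 3 gives 6200 nM; both lie beyond the scatter from compound 1. Compound 4, `CCCCCC(C)OC(=O)CC(=O)Nc1c(C(C)C)cccc1C(C)C`, has not yet been measured. It differs from compound 1 in a single place: hydrogen in place of pentyl on a saturated chain carbon, six bonds along the chain from an oxygen next to a carbonyl group. Among the compounds with values here, no measured pair shows a change of this kind, so the expectation rests on compound 1 alone and is uncertain. The step from compound 1 to compound 4 is expected to be a 6.7-fold higher number from compound 1 to compound 4 (0.82 log units; beyond the scatter), toward a higher number. Compound 4 is estimated at 40 nM, with a range from 10 nM to 200 nM.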

Compound 4, half-maximal inhibitory concentration: 27 nM
Beside the measured number, compound 4's estimate is 1.5-fold (0.17 log units) above it; low and high end bracket the measured number.
By their numbers in this assay, from the lowest: compound 1; then compound 4; then compound 2; then compound 3.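

In this assay, within the data shown here, the swap of pentyl for hydrogen at this saturated chain carbon gives a 4.5-fold higher number from compound 1 to compound 4 (0.65 log units; beyond the scatter) and so gives the first direct reading of what the outer part of the ester chain contributes. The step is modest: shortening the chain weakens inhibition but does not abolish it. Nothing here gives a reason for this step. Going by these compounds, two chain lengths cannot define a trend, so the best length remains unknown. On these data alone, whether a longer chain would lower the number further, or how an amine or a carboxylic acid at the chain end would read, stays open.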